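Swapping a Furan for a Substituted Phenol

The compounds below may be only part of what the source reports. "The series", "measured", "known", "first", "only" and "open" are said of these compounds alone.

Of the compounds shown here, two that share a core have been tested in an ADME assay on HepG2 cells (Homo sapiens) for cytotoxicity, read by luminescence, CellTiter-Glo and ATP content, with a stated time of 72 h; on this read-out higher numbers stand for an effect only at larger amounts of compound and lower numbers for an effect already at smaller amounts. Compound 1 `FC(F)(F)c1cc(-c2ccc3c(NCCCNCc4ccco4)ccnc3c2)cc(C(F)(F)F)c1` gives 2410 nM in this assay. Compound 2 `COc1ccc(-c2ccc3c(NCCCNCc4cc(F)ccc4OC)ccnc3c2)cc1` gives 5960 nM in this assay, which leaves compound 1 with the lower of the two numbers, its neighbour compound 2 standing beyond the usual scatter above it. The two compounds differ in more than one place, so their gap cannot be tied to any single group.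

Compound 3 `COc1cccc(CNCCCNc2ccnc3cc(-c4cc(C(F)(F)F)cc(C(F)(F)F)c4)ccc23)c1O` has not yet been measured. It departs from compound 1 by a single change: 2-hydroxy-3-methoxyphenyl in place of furan-2-yl on a saturated chain carbon bound to an amine nitrogen. Among the compounds with values here, no measured pair shows exactly this change on this core, so nothing in the data says how this assay will answer it. With only two measured points, neither of which isolates this swap, the expectation is that the step from compound 1 to compound 3 in this assay, a 1.2-fold higher number from compound 1 to compound 3 (0.10 log units; within the scatter), stays within the usual scatter, with no clear direction. Compound 3 is therefore estimated at 3000 nM in this assay, within a range of 1200 nM to 8000 nM.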

Compound 3, half-maximal effective concentration: 940 nM
For compound 3 the middle estimate is 3.2-fold (0.50 log units) above the measured one; measured number below the stated range.
By their numbers in this assay, from the lowest: compound 3; then compound 1; then compound 2.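

Within the data shown here, this is the first pair here that differs in one place only, so a gap can be tied to a single change: in this assay, putting 2-hydroxy-3-methoxyphenyl in place of furan-2-yl on a saturated chain carbon bound to an amine nitrogen gives a 2.6-fold lower number from compound 1 to compound 3 (0.41 log units; beyond the scatter), a modest step but one beyond the usual scatter. The group at this place therefore matters on its own: with the rest of compound 1 held fixed, the effect on the cells appears at a smaller amount of compound. The swap changes several things at once, replacing a five-membered aromatic ring with one hetero atom by a six-membered ring of carbon only and adding a hydrogen-bond donor, and nothing at hand says which of these differences counts.

The compounds shown do not separate the hydroxy group from the methoxy group, and a plain benzyl, a 2-hydroxybenzyl or a 3-methoxybenzyl group at this place would pull the two apart. Also open, from the compounds shown here alone, is whether the same swap would give a step of similar size with the other groups that compound 2 carries.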